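This account rests on a few compounds, and the source may have more. Where it says the series, first, only, none or still open, it means among the compounds named here.

Compound 1, `Cc1[nH]c(=O)n(C)c1-c1ccc(Oc2ccccc2)cc1`, gives 8100 nM in a functional assay on brain (Rattus norvegicus, strain Wistar) for inhibition; a higher number here means a weaker inhibitor, a lower number a stronger inhibitor.
Compound 2, `Cc1[nH]c(=O)n(C)c1-c1ccc(OCc2ccccc2)cc1`, gives 6700 nM in this assay.
Compound 3, `Cc1[nH]c(=O)n(C2CCCCC2)c1-c1ccc(Oc2ccccc2)cc1`, gives 7900 nM in this assay.

These three compounds share a core and differ from one another at two places. Between compound 1 and compound 2 the change is benzyl in place of phenyl on an oxygen on an aromatic ring, and the step it made was a 1.2-fold lower number from compound 1 to compound 2 (0.08 log units; within the scatter). Between compound 1 and compound 3 the cores differ by cyclohexyl in place of methyl on an aromatic nitrogen, and that step was a 1.0-fold lower number from compound 1 to compound 3 (0.01 log units; within the scatter). All three numbers thus sit close together, and none of them can be set apart from the others.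

Compound 4, `Cc1[nH]c(=O)n(C2CCCCC2)c1-c1ccc(OCc2ccccc2)cc1`, has not yet been measured. Within the data shown here, it carries the same change as the one from compound 1 to compound 2, now made on the core of compound 3: benzyl in place of phenyl on an oxygen on an aromatic ring. The place where the groups are swapped reads the same word for word in both pairs, so this is the same change, made twice among the compounds shown.

Since the earlier step, a 1.2-fold lower number from compound 1 to compound 2 (0.08 log units; within the scatter), stayed within the scatter, the step from compound 3 to compound 4 is also expected to stay within it, estimated as a 1.2-fold lower number from compound 3 to compound 4 (0.08 log units; within the scatter). Among the measured compounds shown here, this expectation rests only on the single earlier example and on the closeness of the number for compound 3, 7900 nM, to the number for compound 1, 8100 nM. The number expected for compound 4 in this assay is 6600 nM, with a range from 3300 nM to 13000 nM.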

Compound 4, half-maximal inhibitory concentration: 8300 nM
Compound 4: middle estimate off by 1.3-fold (0.10 log units), on the low side; low and high end bracket the measured number.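

In this assay, benzyl in place of phenyl on the oxygen gave a 1.1-fold higher number from compound 3 to compound 4 (0.02 log units; within the scatter), and the change behaves alike on the two cores: the same change on two cores in this assay, a 1.2-fold lower number (0.08 log units; within the scatter) from compound 1 to compound 2 and a 1.1-fold higher number (0.02 log units; within the scatter) from compound 3 to compound 4, 1.3-fold (0.10 log units) apart, within the scatter of two such steps. Cyclohexyl in place of methyl on the aromatic nitrogen gave a 1.2-fold higher number from compound 2 to compound 4 (0.09 log units; within the scatter), and this change also reads alike whichever group stands on the oxygen: the same change on two cores in this assay, a 1.0-fold lower number (0.01 log units; within the scatter) from compound 1 to compound 3 and a 1.2-fold higher number (0.09 log units; within the scatter) from compound 2 to compound 4, 1.3-fold (0.10 log units) apart, within the scatter of two such steps. Across these four compounds, then, neither change moves the number beyond the scatter on either core, but this agreement is only between steps too small to read, so it does not show that a change with a clear effect would carry from one core to another in the same way.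

The compounds shown leave open whether any group at these two places can set one compound clearly apart from the others, for instance an amine or a carboxylic acid on the ring of the benzyl group, a longer chain on the oxygen, or a plain hydrogen on the aromatic nitrogen. They also leave open whether a step of that larger kind would keep its size when made on a second core.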